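The compounds below may be only part of what the source reports. "The series", "measured", "known", "first", "only" and "open" are said of these compounds alone.

Of the compounds shown here, three have been tested so far in a functional assay on SK-MEL-28 cells (Homo sapiens) for cytotoxicity, read by MTT assay, with a stated time of 72 h; on this read-out lower numbers stand for stronger inhibition and higher numbers for weaker inhibition. Compound 1 `COc1cc(/C=C/C=O)cc(OC)c1OC/C=C(\C)CCC=C(C)C` gives 26000 nM. Compound 2 `CC(C)=CCOc1ccc(C(=O)/C=C/c2ccccc2)c(O)c1` gives 81000 nM, the higher of the two actual numbers, and its gap to compound 1 lies beyond the usual scatter. Compound 3 `C=C(C)CCOc1c(OC)cc(/C=C/CO)cc1OC` reads > 100000 nM, which is a limit of the assay and not a number.

Compound 2 therefore sits at the weak end of the measured numbers, with only the limit of compound 3 as a further reference. Compound 4 `CC(C)=CCOc1ccc(C(=O)/C=C/c2ccc(O)cc2)c(O)c1` has not yet been measured in this assay. It differs from compound 2 in one place: hydroxy in place of hydrogen on an aromatic carbon. A hydroxy takes the place of a hydrogen on an aromatic carbon, para to a large group, so that phenyl becomes 4-hydroxyphenyl.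

No measured pair among these compounds shows what this change does, so the expectation starts from compound 2 at 81000 nM. A small move toward a lower number is expected, not clearly beyond the scatter, and the expected step is a 1.6-fold lower number from compound 2 to compound 4 (0.21 log units; within the scatter). For compound 4 the estimated value is 50000 nM, with an expected range from 20000 nM to 100000 nM.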

Compound 4, half-maximal inhibitory concentration: > 100000 nM
Compound 4: only a limit was reported; the forecaster's own chance of this, stated with the estimate: 20%; at least 2.0-fold (0.30 log units) between middle value and limit.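

In this assay, compound 4 gives > 100000 nM, which is a limit of the assay and not a number. Going by these compounds alone, this is the first reading of a change of this kind, para to a large group, and the change from phenyl to 4-hydroxyphenyl gives an at least 1.2-fold higher number from compound 2 to compound 4 (0.09 log units; that floor lies within the scatter), so it brings no lower number at this position, although the printed floor of the step does not establish a real rise. The true size of the step cannot be read, and the scale leaves little room over compound 2 for showing one: the limit of > 100000 nM in this assay, at which 2 of the 4 values shown sit.

The compounds shown leave open whether a different group at this same place, such as a methoxy, an amine, a fluorine or a carboxylic acid, would move the number down from that of compound 2 or would also end at the limit. They also leave open whether hydroxy in place of hydrogen would act in the same way on another core, such as that of compound 1, where the reading would start from a lower number.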